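Cyano in place of fluoro: next step in the series

The source may report more compounds than this note shows. Statements on the series, on what has been measured and on what is new or still open speak of the compounds shown alone.

Compound 1 `Nc1ccccc1NC(=O)c1ccc(CSC(=S)N2CCN(Cc3ccccn3)CC2)cc1` and compound 2 `Nc1ccccc1NC(=O)c1ccc(CSC(=S)N2CCN(c3ccc(F)cc3)CC2)cc1` share one core and differ only in the group on the amine nitrogen in the ring. In a functional assay on MGC-803 cells (Homo sapiens) for antiproliferative activity, read by CCK-8 assay, with a stated time of 72 h, tested at 8 uM (a lower number here means a weaker effect, a higher number a stronger effect of the compound at the concentration tested), compound 1 gives 65.2%, while compound 2 gives 48.7%, the lower of the two numbers in hand; the step is a number 16.5 percentage points lower from compound 1 to compound 2 (beyond the scatter). Compound 3 `N#Cc1ccc(N2CCN(C(=S)SCc3ccc(C(=O)Nc4ccccc4N)cc3)CC2)cc1` carries cyano in place of fluoro on an aromatic carbon. Among the compounds with values here, no measured step exchanges one substituent for another on that aromatic ring; the single step available, 4-fluorophenyl in place of (pyridin-2-yl)methyl, alters a different part of the molecule and gives no direct guide. Within the data shown here, with no bearing step, the expected step in this assay is a number 1.3 percentage points higher from compound 2 to compound 3 (within the scatter), within the scatter. For compound 3 the estimated value in this assay is 50%, with a range from 35% to 65%.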

Compound 3, a percentage reported as inhibition, at one concentration (the size of the read-out at that concentration, not a potency): 37.6%
For compound 3 the middle estimate is 12.4 percentage points above the measured one, within the range that was stated.
By their numbers in this assay, from the lowest: compound 3; then compound 2; then compound 1.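

Within the data shown here, the substituent on this aromatic carbon does matter: in this assay cyano in place of fluoro gives a number 11.1 percentage points lower from compound 2 to compound 3 (beyond the scatter), the first measured change at this position, and the step lies beyond the scatter. With 4-cyanophenyl in place of (pyridin-2-yl)methyl on the ring amine nitrogen, the read-out shows a number 27.6 percentage points lower from compound 1 to compound 3 (beyond the scatter), which leaves compound 3 as the weakest of the three at the single concentration tested. Nothing available bears on why the cyano group gives the lower number.

With only fluoro and cyano read on this aromatic carbon, two substituents cannot define a trend, and an amine, a methoxy group or a chlorine there could fall on either side of them. Also open, on these data alone, is whether the same exchange would give a similar step on a different group at the ring amine nitrogen, such as a benzyl group.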